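The source may report more compounds than this note shows. Statements on the series, on what has been measured and on what is new or still open speak of the compounds shown alone.

Going by the values given here, in a physicochemical assay for lipophilicity, at pH 7.4 (a higher number here means a more lipophilic compound, a lower number a more polar compound), compound 2 `Cc1c(CN2CCCC2)cc(-c2ccc(C(F)(F)F)cc2)n1Nc1ccnc2cc(Cl)ccc12` gives 4.72, the highest of the three numbers measured so far. Compound 1 `Cc1c(CN2CCCC2)cc(-c2ccc(Cl)cc2)n1Nc1ccnc2cc(Cl)ccc12` gives 4.06, and compound 3 `Cc1ccc(-c2cc(CN3CCCC3)c(C)n2Nc2ccnc3cc(Cl)ccc23)cc1` gives 3.91; both of these sit beyond the scatter below compound 2. Compound 4 `Cc1c(CN2CCCC2)cc(-c2ccc(N)cc2)n1Nc1ccnc2cc(Cl)ccc12` has not yet been measured. It differs from compound 2 in one place: amino in place of trifluoromethyl on an aromatic carbon. Among the compounds with values here, two measured steps bear on this change. Both swap the same trifluoromethyl for another group on that aromatic carbon: a number 0.66 log units higher from compound 1 to compound 2 (beyond the scatter) and a number 0.81 log units lower from compound 2 to compound 3 (beyond the scatter). In each case the trifluoromethyl compound was the more lipophilic, by a modest margin. In compound 4 the group that enters is amino, which, unlike chloro or methyl, carries a hydrogen-bond donor and a hydrogen-bond acceptor, so a larger drop in this assay than either of those two steps is expected, a number 2.02 log units lower from compound 2 to compound 4 (beyond the scatter). Compound 4 is therefore estimated to give 2.7, with a likely range from 2.1 to 3.3.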

Compound 4, distribution coefficient: 2.03
Beside the measured number, compound 4's estimate is 0.67 log units above it; the whole stated range lies above it.
By their numbers in this assay, from the lowest: compound 4; then compounds 3 and 1 (each within the scatter of the next); then compound 2.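

Amino on this aromatic carbon moves the reading in this assay far more than any earlier swap did, with a number 2.69 log units lower from compound 2 to compound 4 (beyond the scatter) in place of trifluoromethyl, a number 1.88 log units lower from compound 3 to compound 4 (beyond the scatter) in place of methyl and a number 2.03 log units lower from compound 1 to compound 4 (beyond the scatter) in place of chloro. The earlier compounds shown here showed only trifluoromethyl standing apart from chloro and methyl; now the step is large whichever of the three groups leaves, and compound 4 lies lowest, with all its steps beyond the scatter. No measurement shown here explains the size of this change.

Going by these compounds, whether so large a step belongs to amino alone stays open, and dimethylamino, hydroxyl or a carboxylic acid on this carbon would test that. All four compounds also share one core, so the same swap on another core remains an open question.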